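A few compounds are considered here, and "the series" means these few. Any claim that something is new, unique, unknown or untested is made for them only; others in the source may bear on it.

Working notes on the amide series. Compound 1 `O=C(Nc1ccc(Cl)c(-c2nnc3c(Cl)cccn23)c1)c1ccc(F)cc1Cl` carries the shared core. In a functional assay on HeLa cells (Homo sapiens) for antiproliferative activity, read by MTT assay, with a stated time of 72 h (on this read-out higher numbers stand for weaker inhibition and lower numbers for stronger inhibition), compound 1 gives > 100000 nM, which is a limit of the assay rather than a number. Compound 2 `O=C(Nc1ccc(Cl)c(-c2nnc3c(Cl)cccn23)c1)c1ccccn1` gives 75500 nM in this assay. Compound 3 `O=C(Nc1ccc(Cl)c(-c2nnc3c(Cl)cccn23)c1)c1cccc(Cl)c1` gives > 100000 nM in this assay, again only a limit. Every measured step exchanges the aryl group on the carbonyl carbon: the step of an at least 1.3-fold lower number from compound 1 to compound 2 (0.12 log units; that floor lies within the scatter) and the step of an at least 1.3-fold higher number from compound 2 to compound 3 (0.12 log units; that floor lies within the scatter) both rest on floors that lie within the scatter, and the step that the two limits leave unreadable from compound 1 to compound 3 cannot be read because of the limit of > 100000 nM in this assay, at which 2 of the 3 values shown sit. Compound 4 `O=C(Nc1ccc(Cl)c(-c2nnc3c(Cl)cccn23)c1)c1c(F)cccc1Cl` is not yet measured and differs from compound 1 by 2-chloro-6-fluorophenyl in place of 2-chloro-4-fluorophenyl on a carbonyl carbon. The three measured steps bear on it only as aryl exchanges of the same kind, and none of them shows a change beyond the scatter, so no step beyond the scatter is expected in this assay in either direction. Compound 4 is therefore estimated at 100000 nM, with a range from 40000 nM to 300000 nM. The expected step of a number no higher from compound 1 to compound 4 (the limit leaves the size open) is essentially none, and a limit is again the likeliest report.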

Compound 4, half-maximal inhibitory concentration: > 100000 nM
Compound 4: only a limit was reported; the forecaster's own chance of this, stated with the estimate: 70%; the middle value lies on the limit itself.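

Compound 4 is a further aryl amide reported only as a limit, so 2-chloro-6-fluorophenyl in place of 2-chloro-4-fluorophenyl on the carbonyl carbon gives no readable change in this assay. The steps from compound 1 and from compound 3 to compound 4 cannot be read, because each pair has both ends at the same limit: the limit of > 100000 nM in this assay, at which 3 of the 4 values shown sit. Going by these compounds alone, the one readable new step, 2-chloro-6-fluorophenyl in place of pyridin-2-yl, is an at least 1.3-fold higher number from compound 2 to compound 4 (0.12 log units; that floor lies within the scatter), so it does not separate the two groups.

Within the data shown here, compound 2 remains the only member of the series with a value that is a number, so the series offers no step beyond the scatter at this position. Open, as far as these compounds go, is whether an amine or a carboxylic acid on the group at the carbonyl carbon would bring a reading clear of the limit.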